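The source may report more compounds than this note shows. Statements on the series, on what has been measured and on what is new or still open speak of the compounds shown alone.

Measured compounds in a functional assay on the whole organism (stomach) with Rattus norvegicus as the target; a lower number here means that less compound is needed, a higher number that more compound is needed for the effect:

Compound 1, `C/N=C(\S)NCCCCCn1nc(-c2ccccc2)ccc1=O`: 35.3 mg/kg.
Compound 3, `N/C(S)=N/CCCCn1nc(-c2ccccc2)ccc1=O`: 36.3 mg/kg.
Compound 2, `O=c1ccc(-c2ccccc2)nn1CCCC/N=C(\S)Nc1cccc(F)c1`: > 100 mg/kg, a limit of the assay rather than a number.

Compound 3 holds the higher of the two numbers, but the step of a 1.0-fold higher number from compound 1 to compound 3 (0.01 log units; within the scatter) lies within the scatter, so no order between these two compounds can be read from them.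

Compound 4, `O=c1ccc(-c2ccccc2)nn1CCCC/N=C(\S)Nc1ccc(F)cc1`, differs from compound 3 by 4-fluorophenyl in place of hydrogen on an amine nitrogen. Among the measured compounds shown here, one measured step bears on this: an at least 2.7-fold lower number from compound 2 to compound 3 (0.44 log units; beyond the scatter), the reverse of a closely related change, with compound 2 sitting at the limit of > 100 mg/kg in this assay, at which 1 of the 3 values shown sits. A rise in the dose is therefore expected, a 3.0-fold higher number from compound 3 to compound 4 (0.48 log units; beyond the scatter), quite possibly beyond the limit again. Compound 4 is estimated at 110 mg/kg, within a range from 45 mg/kg to 300 mg/kg.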

Compound 4, dose for half-maximal effect: > 100 mg/kg
Compound 4: a limit, no number; the forecaster's own chance of this, stated with the estimate: 60%; the middle value does not contradict the limit.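

In this assay, among the compounds shown here, placing 4-fluorophenyl on the amine nitrogen gives an at least 2.7-fold higher number from compound 3 to compound 4 (0.44 log units; beyond the scatter) in the dose, so the 3-fluorophenyl group of compound 2 is no longer the only fluorophenyl group tied to a higher number at this position. Compound 4 gives a limit of the assay, as compound 2 does, so the step between them cannot be read and the two fluorine positions cannot be ranked: the limit of > 100 mg/kg in this assay, at which 2 of the 4 values shown sit.

On these data alone, whether unsubstituted phenyl or benzyl on this nitrogen would also raise the dose stays open. So does how far compound 2 and compound 4 lie beyond their limits.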